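The source may report more compounds than this note shows. Statements on the series, on what has been measured and on what is new or still open speak of the compounds shown alone.

Of the compounds shown here, two have been measured in an in vitro functional assay on cells for agonist activity at Bombesin receptor subtype-3 (Homo sapiens), read by luminescence and calcium flux; a lower number here means that less compound is needed, a higher number that more compound is needed for the effect. Compound 1, with the structure `CCCCc1cnc(C(CCCC)Cc2ccc(-c3ccccc3C(=O)O)cc2)[nH]1`, gives 2660 nM in this assay. Compound 2, with the structure `O=C(O)c1ccccc1-c1ccc(CCc2ncc(-c3ccccc3)[nH]2)cc1`, gives 4950 nM in this assay. Of the two numbers, that of compound 2 is the larger, but its gap to compound 1 is within the scatter of repeated measurements, so the two compounds cannot be separated on these data.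

The next compound, compound 3, has the structure `CC(C)(C)Cc1cnc(CCc2ccc(-c3ccccc3C(=O)O)cc2)[nH]1` and has not yet been measured in this assay. It differs from compound 2 in one place: neopentyl in place of phenyl on an aromatic carbon. The change is neopentyl in place of phenyl on an aromatic carbon, with the rest of the shared core unchanged.

Among the measured compounds shown here, no step between measured compounds is available to guide the expectation. Compound 1 carries an open-chain group at the same position and gives 2660 nM, a number that is within the scatter of compound 2. The expected step from compound 2 to compound 3 in this assay is therefore small, a 1.5-fold lower number from compound 2 to compound 3 (0.19 log units; within the scatter), not clearly beyond the scatter. Compound 3 is estimated at 3200 nM, with a range from 1000 nM to 10000 nM.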

Compound 3, half-maximal effective concentration: 106 nM
Compound 3: the middle estimate sits 30-fold (1.48 log units) above what was measured; the measured number lies below the stated range.
By their numbers in this assay, from the lowest: compound 3; then compounds 1 and 2 (each within the scatter of the next).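

In this assay, the position on the five-membered aromatic ring with 2 nitrogen proves sensitive to the group it carries: neopentyl in place of phenyl gives a 47-fold lower number from compound 2 to compound 3 (1.67 log units; beyond the scatter). Compound 1 and compound 2 could not show this, as they differ in more than one place and their numbers lie within the scatter of each other. The change replaces a six-membered aromatic ring of carbon only, with 6 heavy atoms, by an open-chain group with 5 heavy atoms, and neither group has hydrogen-bond donors or acceptors, but no measurement here explains the size of the step.

The compounds shown do not separate the loss of the aromatic ring from the gain of the branched chain, and a cyclohexyl ring or an unbranched butyl chain at this position on the core of compound 3 would bear on that. From the compounds shown here alone, it also remains open whether an amine or a hydroxyl group on the neopentyl chain would keep the low number of compound 3 (106 nM).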